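Same Aryl Swap Carried onto a Second Core

The compounds below may be only part of what the source reports. "The series", "measured", "known", "first", "only" and "open" are said of these compounds alone.

Compound 1 `N#Cc1cc(Cl)ccc1/C(=C(\c1ccc(/C=C/C(=O)O)cc1)c1ccc2nccn2c1)C1CCC1` is tested in a functional assay on MCF7 cells (Homo sapiens) for antiproliferative activity, read by CellTiter-Glo, with a stated time of 5 days (a lower number here means a stronger inhibitor, a higher number a weaker inhibitor), and gives 5.9 nM. Compound 2 `O=C(O)/C=C/c1ccc(/C(=C(\c2ccc(C(F)(F)F)cc2Cl)C2CCC2)c2ccc3nccn3c2)cc1` differs from compound 1 in one place, (2-chloro-4-(trifluoromethyl)phenyl in place of 4-chloro-2-cyanophenyl on a double-bonded chain carbon bound to a double-bonded chain carbon and a saturated ring carbon), and in this assay compound 2 gives 5.1 nM; the step is a 1.2-fold lower number from compound 1 to compound 2 (0.06 log units; within the scatter). Compound 3 `N#Cc1cc(Cl)ccc1/C(=C(\c1ccc(/C=C/C(=O)O)cc1)c1ccc(-c2cn[nH]c2)cc1)C1CCC1` carries a different core from compound 1, (a group of 11 heavy atoms (9 carbon, 2 nitrogen; one five-membered aromatic ring with 2 hetero atoms, one six-membered aromatic ring of carbon only) in place of a group of 9 heavy atoms (7 carbon, 2 nitrogen; one five-membered aromatic ring with 2 hetero atoms, one six-membered aromatic ring with 1 hetero atom), on a double-bonded chain carbon bound to an aromatic carbon and a double-bonded chain carbon), and in this assay compound 3 gives 4.4 nM, the step being a 1.3-fold lower number from compound 1 to compound 3 (0.13 log units; within the scatter). All three values lie within the scatter of one another.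

Compound 4 `O=C(O)/C=C/c1ccc(/C(=C(\c2ccc(C(F)(F)F)cc2Cl)C2CCC2)c2ccc(-c3cn[nH]c3)cc2)cc1` is not yet measured. It stands to compound 3 as compound 2 stands to compound 1, the same change at the same place: 2-chloro-4-(trifluoromethyl)phenyl in place of 4-chloro-2-cyanophenyl on a double-bonded chain carbon bound to a double-bonded chain carbon and a saturated ring carbon. Because the earlier instance of this change gave a 1.2-fold lower number from compound 1 to compound 2 (0.06 log units; within the scatter), the change on the core of compound 3 is expected to leave the number essentially where it is, and compound 4 is expected to show a step of a 1.2-fold lower number from compound 3 to compound 4 (0.06 log units; within the scatter). For compound 4 the estimate in this assay is 3.8 nM, expected to fall between 2 nM and 7.5 nM.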

Compound 4, half-maximal inhibitory concentration: 16 nM
Compound 4: the middle estimate sits 4.2-fold (0.62 log units) below what was measured; measured number above the stated range.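

In this assay, putting 2-chloro-4-(trifluoromethyl)phenyl in place of 4-chloro-2-cyanophenyl did not have the same outcome on the second core, giving a 3.6-fold higher number from compound 3 to compound 4 (0.56 log units; beyond the scatter), and the two instances of the change differ: the same change on two cores in this assay, a 1.2-fold lower number (0.06 log units; within the scatter) from compound 1 to compound 2 and a 3.6-fold higher number (0.56 log units; beyond the scatter) from compound 3 to compound 4, 4.2-fold (0.62 log units) apart, beyond the scatter of two such steps. Seen from the other side, the change of core also depends on which aryl group is present, giving a 3.1-fold higher number from compound 2 to compound 4 (0.50 log units; beyond the scatter), which differs from the earlier core step: the same change on two cores in this assay, a 1.3-fold lower number (0.13 log units; within the scatter) from compound 1 to compound 3 and a 3.1-fold higher number (0.50 log units; beyond the scatter) from compound 2 to compound 4, 4.2-fold (0.62 log units) apart, beyond the scatter of two such steps. Among these four compounds, then, the result of the aryl swap cannot be carried from one core to the other, but this rests on only two instances and does not show why they differ or how the swap would behave on a further core.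

The compounds shown leave open how a methoxy-substituted phenyl or an unsubstituted phenyl would behave at the same place on each core. They also leave open whether the gap between the two instances of the swap would appear in a different cell line.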